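Exchanging the aryl group on the shared core

The source may hold more compounds than are shown below. What is called first, only, known or untested is meant among the compounds shown, and "the series" means these compounds.

Compound 1, `O=C(O)c1ccccc1-c1ccc(CCc2ncc(CC3CCOCC3)[nH]2)cc1`: 338 nM
Compound 2, `CCC(C)(C)Cc1c[nH]c(CCc2ccc(-c3ccccc3C(=O)O)cc2)n1`: 25 nM
Compound 3, `O=C(O)c1ccccc1-c1ccc(CCc2ncc(Cc3cccc(F)c3)[nH]2)cc1`: 159 nM

These three compounds share one core and differ only in the group on a saturated chain carbon bound to an aromatic carbon. In an in vitro functional assay on cells for agonist activity at Bombesin receptor subtype-3 (Homo sapiens), read by luminescence and calcium flux (on this read-out higher numbers stand for an effect only at larger amounts of compound and lower numbers for an effect already at smaller amounts), compound 3 gives 159 nM, the second highest of the three numbers. Within the data shown here, the one single-point step among them is a 2.1-fold lower number from compound 1 to compound 3 (0.33 log units; beyond the scatter). Among the measured compounds shown here, compound 2 gives a lower number than compound 3, but no single step connects them.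

Compound 4, `N#Cc1ccccc1Cc1cnc(CCc2ccc(-c3ccccc3C(=O)O)cc2)[nH]1`, carries 2-cyanophenyl in place of 3-fluorophenyl on a saturated chain carbon bound to an aromatic carbon. The measured step of a 2.1-fold lower number from compound 1 to compound 3 (0.33 log units; beyond the scatter) concerns a saturated ring giving way to an aryl, so it says little about trading one aryl for another, and nothing else measured here addresses such an exchange. The expected outcome is therefore no step beyond the scatter, a 1.0-fold higher number from compound 3 to compound 4 (0.00 log units; within the scatter). Compound 4 is estimated at 160 nM, between 60 nM and 450 nM.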

Compound 4, half-maximal effective concentration: 5480 nM
Estimate against measurement, compound 4: 34-fold (1.53 log units) below; measured number above the stated range.
By their numbers in this assay, from the lowest: compound 2; then compound 3; then compound 1; then compound 4.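

Aryl groups are not interchangeable at this position: in this assay, 2-cyanophenyl in place of 3-fluorophenyl gives a 34-fold higher number from compound 3 to compound 4 (1.54 log units; beyond the scatter) and so a large change where the earlier step was modest. Set against oxan-4-yl, the same group gives a 16-fold higher number from compound 1 to compound 4 (1.21 log units; beyond the scatter) and thus reverses the direction seen with 3-fluorophenyl in compound 3, so an aryl group here does not by itself lower the number. Nothing available explains this loss.

Open, from the compounds shown here alone, is whether the change follows the nitrile itself or its ring position, which 3-cyanophenyl and 2-fluorophenyl groups at this place would separate.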